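From 5-methylfuran-2-yl to 4-chlorophenyl on the shared core

The source may report more compounds than this note shows. Statements on the series, on what has been measured and on what is new or still open speak of the compounds shown alone.

In a functional assay on HeLa cells (Homo sapiens) for cytotoxicity, read by ELISA, with a stated time of 4 days (a higher number here means a weaker inhibitor, a lower number a stronger inhibitor), compound 3 (`Cc1ccc(-c2cc(-c3ccoc3)cc(-c3ccc(Cl)s3)n2)o1`) gives 26500 nM and sits among close neighbours. Compound 1 (`Cc1ccsc1-c1cc(-c2ccco2)cc(-c2ccccc2Cl)n1`) gives 24000 nM on the same read-out and compound 2 (`Cc1ccsc1-c1cc(-c2ccco2)cc(-c2ccc(Cl)cc2)n1`) gives 24500 nM there, so compound 3 lies within the scatter of both.

Compound 4 (`Clc1ccc(-c2cc(-c3ccoc3)cc(-c3ccc(Cl)s3)n2)cc1`) carries 4-chlorophenyl in place of 5-methylfuran-2-yl on an aromatic carbon, next to the ring nitrogen. Among the measured compounds shown here, no measured pair makes this exchange directly, so the evidence is indirect. For the measured compounds named here, the one measured step, 4-chlorophenyl in place of 2-chlorophenyl, is a 1.0-fold higher number from compound 1 to compound 2 (0.01 log units; within the scatter) and stays within the scatter. Going by the values given here, it shows only that a chlorophenyl group can take a different form without a visible shift in these compounds. A step beyond the scatter is therefore not expected, though the support is thin. The expected step is a 1.1-fold lower number from compound 3 to compound 4 (0.03 log units; within the scatter) with no clear direction. In this assay the estimated value for compound 4 is 25000 nM with an expected range from 12000 nM to 50000 nM as its bounds.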

Compound 4, half-maximal inhibitory concentration: 16500 nM
Compound 4: the middle estimate sits 1.5-fold (0.18 log units) above what was measured; measured number inside the range.
By their numbers in this assay, from the lowest: compounds 4, 1, 2 and 3 (each within the scatter of the next).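

In this assay, exchanging 5-methylfuran-2-yl for 4-chlorophenyl next to the ring nitrogen gives a 1.6-fold lower number from compound 3 to compound 4 (0.21 log units; within the scatter), the first step read directly at this position, and it stays within the scatter. With the 5-chlorothiophen-2-yl and furan-3-yl groups held in place, a five-membered aromatic ring with a hydrogen-bond acceptor can thus give way to a six-membered aromatic ring of carbon only, with no hydrogen-bond acceptors and one more heavy atom, without a step beyond the scatter. No measured property of either group bears on this result.

Both groups at this position are aromatic rings, so the compounds shown do not tell how an aliphatic amine or a carboxylic acid would read there. They also leave open whether a step beyond the scatter can be reached at this position at all.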